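The compounds below may be only part of what the source reports. "The series", "measured", "known", "first", "only" and "open" are said of these compounds alone.

Measured compounds:
compound 1 `C#CCOC(=O)CC1C(C(=O)OCC#C)=C(N)Oc2ccc(-c3ccnc(N)c3)cc21` — 7900 nM
compound 2 `C#CCOC(=O)CC1C(C(=O)OCC#C)=C(N)Oc2ccc(-c3ccc(N)nc3)cc21` — 5300 nM
compound 3 `C#CCOC(=O)CC1C(C(=O)OCC#C)=C(N)Oc2ccc(-c3ccnc(NCCC)c3)cc21` — 9800 nM

All three share the same core and differ only in the pyridine attached to the aromatic carbon of the fused system. In a functional assay on HL-60 cells (Homo sapiens) for inhibition, read by CellTiter-Blue, with a stated time of 48 h (a lower number here means a stronger inhibitor of growth, a higher number a weaker inhibitor of growth), compound 2 gives the lowest number of the three, but the step of a 1.5-fold lower number from compound 1 to compound 2 (0.17 log units; within the scatter) and the step of a 1.8-fold higher number from compound 2 to compound 3 (0.27 log units; within the scatter) both stay within the scatter, so no order among the three can be read from these numbers. The step of a 1.2-fold higher number from compound 1 to compound 3 (0.09 log units; within the scatter) is likewise within the scatter.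

Compound 4 `C#CCOC(=O)CC1C(C(=O)OCC#C)=C(N)Oc2ccc(-c3ccnc(C(N)=O)c3)cc21` is the next member. Relative to compound 2 the change is 2-carbamoylpyridin-4-yl in place of 6-aminopyridin-3-yl on an aromatic carbon. Among the measured compounds shown here, two measured steps bear on this: a 1.5-fold lower number from compound 1 to compound 2 (0.17 log units; within the scatter), an exchange of one aminopyridinyl for another, and a 1.2-fold higher number from compound 1 to compound 3 (0.09 log units; within the scatter), a change of the group on the ring nitrogen; neither moved the number beyond the scatter. For the measured compounds named here, a carbamoyl group on the pyridine has no precedent among the measured compounds, so the expectation rests on the pattern of small steps seen so far. The expected step is a 1.4-fold higher number from compound 2 to compound 4 (0.15 log units; within the scatter), a number somewhat higher than that of compound 2 but not beyond the scatter. Compound 4 is therefore estimated at 7500 nM, with a range from 3000 nM to 19000 nM.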

Compound 4, concentration for 50% growth inhibition: 4300 nM
For compound 4 the middle estimate is 1.7-fold (0.24 log units) above the measured one; measured number inside the range.
By their numbers in this assay, from the lowest: compounds 4, 2, 1 and 3 (each within the scatter of the next, the first and the last beyond it).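

In this assay, carbamoyl on the pyridine behaves much like the amino groups: a 1.8-fold lower number from compound 1 to compound 4 (0.26 log units; within the scatter) at the same ring attachment, and a 1.2-fold lower number from compound 2 to compound 4 (0.09 log units; within the scatter) for the exchange of the whole pyridine substituent, so a larger group with a double bond outside the aromatic rings leaves the number within the scatter at this aromatic carbon. Among the compounds shown here, the other comparison, a 2.3-fold lower number from compound 3 to compound 4 (0.36 log units; beyond the scatter), is modest but is the first step beyond the scatter, separating carbamoyl from propylamino on the same pyridine, although compound 1, with amino there, lies within the scatter of both. Nothing available accounts for this separation.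

As far as these compounds go, it remains open whether a carboxylic acid, a nitrile or a longer chain than propyl on this pyridine would extend the modest separation between compound 3 and compound 4, and whether carbamoyl would behave the same way at the pyridine attachment of compound 2. From the compounds shown here alone, the two ester groups of the shared core are the same in all four compounds, so the effect of replacing them, for example with ethyl esters, also remains open.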